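The compounds below may be only part of what the source reports. "The series", "measured", "known", "first", "only" and "open" are said of these compounds alone.

Of the compounds shown here, three have been measured so far: compound 1 `CCc1cc(=O)c2ccc(OCc3ccccc3)c(C)c2o1`, compound 2 `CCc1cc(=O)c2ccc(OCc3cccc(C(F)(F)F)c3)c(C)c2o1` and compound 3 `CCc1oc2c(C)c(OCc3ccccc3)ccc2c(=O)c1Br`. In a functional assay on A549 cells (Homo sapiens) for antiproliferative activity, read by sulforhodamine B assay, with a stated time of 72 h (on this read-out higher numbers stand for weaker inhibition of growth and lower numbers for stronger inhibition of growth), compound 1 reaches only the limit of the assay, > 33900 nM. Compound 2 likewise gives only a limit in this assay, > 27600 nM. Compound 3 also stands at a limit in this assay, > 26700 nM. Compound 3 therefore has no number of its own, and the two values beside it are limits as well. The step that the two limits leave unreadable from compound 1 to compound 2 cannot be read, and the same holds for a step that the two limits leave unreadable from compound 1 to compound 3.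

Compound 4 `CCc1oc2c(C)c(OCc3cccc(C(F)(F)F)c3)ccc2c(=O)c1Br` differs from compound 3 by trifluoromethyl in place of hydrogen on an aromatic carbon. For the measured compounds named here, the one measured step with the same change, a step that the two limits leave unreadable from compound 1 to compound 2, stays unreadable because the limit of > 33900 nM in this assay, at which 1 of the 3 values shown sits, and the limit of > 27600 nM in this assay, at which 1 of the 3 values shown sits, bracket nothing but two limits. Going by the values given here, no measured step gives a size. The step for compound 4 is therefore expected to be a step that the limit leaves unreadable from compound 3 to compound 4, and no shift beyond the scatter is claimed for it. Compound 4 is expected to give 30000 nM in this assay, within 10000 nM to 100000 nM. Most likely compound 4 will again be reported only as a limit.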

Compound 4, concentration for 50% growth inhibition: > 22600 nM
Compound 4: a limit, no number; the forecaster's own chance of this, stated with the estimate: 85%; the middle value does not contradict the limit.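

Compound 4 also gives only a limit in this assay, > 22600 nM, and the steps to compound 4 from compound 2 and from compound 3 cannot be read. The compounds shown leave open whether trifluoromethyl or bromo in place of hydrogen on an aromatic carbon changes growth inhibition at all, and what actual number any of the four compounds would give.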